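The source may hold more compounds than are shown below. What is called first, only, known or untested is meant among the compounds shown, and "the series" means these compounds.

Working notes on the series. Compound 1 `Cc1ccc(-c2cn(-c3cc4ccc(O)c(C)c4oc3=O)nn2)cc1` gives 23200 nM in a functional assay on MCF7 cells (Homo sapiens) for antiproliferative activity; a higher number here means a weaker inhibitor, a lower number a stronger inhibitor. Within the data shown here, compound 2 `Cc1c(O)ccc2cc(-n3cc(/C=C/c4ccccc4)nn3)c(=O)oc12` gives 33700 nM in this assay; the step of a 1.5-fold higher number from compound 1 to compound 2 (0.16 log units; within the scatter) is the only measured step, and compound 2 stands as the highest of the two numbers, with compound 1 within the scatter of it. Compound 3 `Cc1c(O)ccc2cc(-n3cc(-c4cc5ccccc5[nH]4)nn3)c(=O)oc12` carries the change (1H-indol-2-yl in place of 2-phenylethenyl on an aromatic carbon). No measured step bears on an indol-2-yl group at this place; the one step shown was within the scatter, so no step beyond the scatter is expected in this assay, in either direction. Compound 3 is therefore expected at 25000 nM, range 8000 nM to 80000 nM, an expected step of a 1.3-fold lower number from compound 2 to compound 3 (0.13 log units; within the scatter).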

Compound 3, half-maximal inhibitory concentration: 38300 nM
Beside the measured number, compound 3's estimate is 1.5-fold (0.19 log units) below it; the range from low to high includes it.
By their numbers in this assay, from the lowest: compounds 1, 2 and 3 (each within the scatter of the next).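

In this assay, 1H-indol-2-yl in place of 2-phenylethenyl gives a 1.1-fold higher number from compound 2 to compound 3 (0.06 log units; within the scatter), and 1H-indol-2-yl in place of 4-methylphenyl gives a 1.7-fold higher number from compound 1 to compound 3 (0.22 log units; within the scatter). Thus a two-ring aromatic group carrying a hydrogen-bond donor is accommodated at this position on the five-membered ring with no step beyond the scatter. No supporting evidence bears on this result. Open, from the compounds shown here alone, is whether a group without an aromatic ring, such as an amine, a carboxylic acid or a longer alkyl chain, would produce a step beyond the scatter here. Changes elsewhere on the shared core also remain open.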